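Replacing benzyl with an open chain on the shared core

The compounds below may be only part of what the source reports. "The series", "measured", "known", "first", "only" and "open" are said of these compounds alone.

Compound 1 `CCCCCCC[C@H]1OC(=O)C[C@H]1OC1CCCCC1` gives 16000 nM
Compound 2 `CCCCCCC[C@H]1OC(=O)C[C@H]1OCc1ccccc1` gives 44000 nM

Both compounds were tested in a functional assay on WiDr cells (Homo sapiens) for antiproliferative activity, read by sulforhodamine B assay, with a stated time of 48 h; a lower number here means a stronger inhibitor of growth, a higher number a weaker inhibitor of growth. Compound 2 has the higher of the two numbers, so it is the weaker growth inhibitor of this pair. For the measured compounds named here, the only measured step is a 2.8-fold higher number from compound 1 to compound 2 (0.44 log units; beyond the scatter), and it comes from benzyl in place of cyclohexyl on an oxygen on a saturated carbon.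

Compound 3 `C=CCC(C)O[C@@H]1CC(=O)O[C@@H]1CCCCCCC` keeps the core of compound 2 but has 1-methylbut-3-en-1-yl in place of benzyl at that oxygen: 1-methylbut-3-en-1-yl in place of benzyl on an oxygen on a saturated carbon. Going by the values given here, this single step is a thin guide, and no compound with an open chain at this place has been measured yet. Like cyclohexyl, the entering group has no aromatic ring. Reading a 2.8-fold higher number from compound 1 to compound 2 (0.44 log units; beyond the scatter) backwards therefore suggests a step of similar size toward a lower number in this assay, although a step within the scatter is also possible. The estimated change is a 2.2-fold lower number from compound 2 to compound 3 (0.34 log units; beyond the scatter). Compound 3 is expected at about 20000 nM, with an estimated range of 8000 nM to 50000 nM.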

Compound 3, concentration for 50% growth inhibition: 39000 nM
Estimate against measurement, compound 3: 2.0-fold (0.29 log units) below; measured number inside the range.
By their numbers in this assay, from the lowest: compound 1; then compounds 3 and 2 (each within the scatter of the next).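

In this assay, the change at this oxygen gives a 1.1-fold lower number from compound 2 to compound 3 (0.05 log units; within the scatter), so benzyl and 1-methylbut-3-en-1-yl cannot be told apart here, even though one carries an aromatic ring and the other has no ring at all. Losing the aromatic ring is therefore not enough to reach the number of compound 1: the open chain also lacks an aromatic ring, yet the comparison with cyclohexyl gives a 2.4-fold higher number from compound 1 to compound 3 (0.39 log units; beyond the scatter). Among these three compounds, compound 1 is the strongest growth inhibitor, with both other groups at this oxygen giving higher numbers, but nothing available here explains what sets cyclohexyl apart.

The compounds shown leave open whether a saturated ring is what matters at this oxygen, a question that a smaller cyclopentyl ring or a saturated open chain such as pentan-2-yl could help to settle. They also do not show whether the double bond of compound 3 has any bearing on its number, or how a group carrying an amine or a carboxylic acid would behave at this place.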